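The source may report more compounds than this note shows. Statements on the series, on what has been measured and on what is new or still open speak of the compounds shown alone.

Compound 3 `O=C(NO)c1ccc(/C=C/c2cncc(-c3ccccc3O)c2)cc1` stands lowest of the three numbers in an assay on isolated protein for inhibition of protein deacetylase HDAC6 (Homo sapiens), read by fluorescence, with a stated time of 15 min (a higher number here means a weaker inhibitor, a lower number a stronger inhibitor), where compound 3 gives 13 nM. Compound 1 `O=C(NO)c1ccc(/C=C/c2ccncc2)cc1` gives 130 nM in this assay, and compound 2 `Cc1ccc(-c2cncc(/C=C/c3ccc(C(=O)NO)cc3)c2)c(F)c1` gives 150 nM; both steps from compound 3 to these are beyond the scatter. Compound 4 `COc1ccc(F)cc1-c1cncc(/C=C/c2ccc(C(=O)NO)cc2)c1` differs from compound 3 in one place: 5-fluoro-2-methoxyphenyl in place of 2-hydroxyphenyl on an aromatic carbon. Within the data shown here, the only measured step that bears on this change is a 12-fold lower number from compound 2 to compound 3 (1.06 log units; beyond the scatter), a large step in which the hydrogen-bond donor on the pendant ring arrived. Since compound 4 removes that donor again while keeping an acceptor, a step back upward is expected, but likely not the whole way, estimated as a 4.6-fold higher number from compound 3 to compound 4 (0.66 log units; beyond the scatter). Compound 4 is thus expected at 60 nM, within a range of 20 nM to 200 nM.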

Compound 4, half-maximal inhibitory concentration: 93 nM
Estimate against measurement, compound 4: 1.6-fold (0.19 log units) below; the measured number falls inside the stated range.
By their numbers in this assay, from the lowest: compound 3; then compounds 4, 1 and 2 (each within the scatter of the next).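

In this assay the change to 5-fluoro-2-methoxyphenyl gives a 7.2-fold higher number from compound 3 to compound 4 (0.85 log units; beyond the scatter) and so shows that an oxygen on the pendant ring does not by itself keep the low number of compound 3. Compound 4 instead lies close to the other compound without a hydrogen-bond donor at this position, with a 1.6-fold lower number from compound 2 to compound 4 (0.21 log units; within the scatter), so among these three rings only 2-hydroxyphenyl stands apart. Nothing given here explains these steps. Still open, from the compounds shown here alone, is whether the fluorine contributes to the rise in compound 4, and how a 2-aminophenyl or an unfluorinated 2-methoxyphenyl group would stand at this position.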